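Adding a methoxy group to a weak growth inhibitor

The source may hold more compounds than are shown below. What is called first, only, known or untested is meant among the compounds shown, and "the series" means these compounds.

Compound 1 `COc1ccc(/C=C/C2CC(=O)C=CO2)cc1OC`: 145 uM
Compound 2 `COc1cc(/C=C/C2CC(=O)C=CO2)cc(OC)c1OC`: 125 uM
Compound 3 `COc1ccc(/C=C/C2CC=CC(=O)N2)cc1`: only a limit, > 1090 uM

All three were tested in a functional assay on 786-0 cells (Homo sapiens) for inhibition, read by sulforhodamine B assay, with a stated time of 48 h; on this read-out lower numbers stand for stronger inhibition of growth and higher numbers for weaker inhibition of growth. Compound 1 and compound 2 share one core and differ by methoxy in place of hydrogen on an aromatic carbon; the step of a 1.2-fold lower number from compound 1 to compound 2 (0.06 log units; within the scatter) is small. Compound 3 has a different core; the difference between the two cores is not broken down here. For compound 3 the assay reports (the limit of > 1090 uM in this assay, at which 1 of the 3 values shown sits), so its true value is not known.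

Compound 4 `COc1ccc(/C=C/C2CC=CC(=O)N2)cc1OC` is not yet measured. It differs from compound 3 by methoxy in place of hydrogen on an aromatic carbon, the same kind of change as from compound 1 to compound 2, though the surroundings of the place differ: in compound 2 the entering methoxy is also meta to a methoxy group, which is not so in compound 4.

Since the same change left compound 1 and compound 2 within the scatter, compound 4 is expected to stay close to compound 3, giving a step that the limit leaves unreadable from compound 3 to compound 4. Compound 4 is therefore estimated at roughly 1500 uM, between 700 uM and 4000 uM, most likely again reported only as a limit.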

Compound 4, concentration for growth inhibition (reported as GI): > 964 uM
Compound 4 gave a limit, no number (the forecaster's own chance of this, stated with the estimate: 80%); the middle value does not contradict the limit.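

In this assay compound 4 gives > 964 uM, a limit and not a number, just as compound 3 does, so no step can be read between compound 3 and compound 4. The compounds shown leave open how strongly these two really inhibit growth, and whether methoxy in place of hydrogen changes anything on their shared core.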